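Methyl for Bromo on a Second Ring Frame

The compounds below may be only part of what the source reports. "The series", "measured", "known", "first", "only" and "open" are said of these compounds alone.

Compound 1 `O=C1/C(=C/c2cccc(Br)c2)Cc2ccccc21` and compound 2 `Cc1cccc(/C=C2\Cc3ccccc3C2=O)c1` share one core; compound 3 `O=C1/C(=C/c2cccc(Br)c2)CCCc2ccccc21` and compound 4 `Cc1cccc(/C=C2\CCCc3ccccc3C2=O)c1` share another, and the difference between the two cores is not broken down here. In a functional assay on P388 cells (Mus musculus) for inhibition (a higher number here means a weaker inhibitor, a lower number a stronger inhibitor), compound 1 gives 21000 nM, compound 2 gives 24900 nM and compound 3 gives 10500 nM. The change methyl in place of bromo on an aromatic carbon gave a 1.2-fold higher number from compound 1 to compound 2 (0.07 log units; within the scatter). The same change, (methyl in place of bromo on an aromatic carbon), now carries compound 3 to compound 4, which is not yet measured in this assay. Because the earlier step of a 1.2-fold higher number from compound 1 to compound 2 (0.07 log units; within the scatter) was small, compound 4 is expected to give 12500 nM, most likely between 7000 nM and 22000 nM. That estimate means a step of a 1.2-fold higher number from compound 3 to compound 4 (0.08 log units; within the scatter), expected to stay within the usual scatter, as the step from compound 1 to compound 2 did.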

Compound 4, half-maximal inhibitory concentration: 19900 nM
For compound 4 the middle estimate is 1.6-fold (0.20 log units) below the measured one, and the stated range covers the measured number.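

In this assay, methyl in place of bromo gave a 1.9-fold higher number from compound 3 to compound 4 (0.28 log units; within the scatter), and this step can be set directly beside the one on the other core: the same change on two cores in this assay, a 1.2-fold higher number (0.07 log units; within the scatter) from compound 1 to compound 2 and a 1.9-fold higher number (0.28 log units; within the scatter) from compound 3 to compound 4, 1.6-fold (0.20 log units) apart, within the scatter of two such steps. On these two cores, then, the change carried over, and in each pair the methyl and bromo compounds lie within the scatter of each other. Two pairs are too few to show that the change would behave the same way on any further core, and they do not explain why the numbers stay so close.

The compounds shown carry only bromo or methyl on that aromatic carbon. As far as these compounds go, what an amine, a carboxylic acid or a longer chain would do there remains open.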